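A Trifluoropropyl Chain on an Already Non-Toxic Core

A few compounds are considered here, and "the series" means these few. Any claim that something is new, unique, unknown or untested is made for them only; others in the source may bear on it.

Compound 1 `CN1C(=S)[C@@H](NC(=O)c2nc(Cc3ccccc3)n(C)n2)COc2ccccc21` was tested in a toxicity assay on HT-29 cells (Homo sapiens) for cytotoxicity; on this read-out lower numbers stand for higher toxicity in this test and higher numbers for lower toxicity in this test. Compound 1 gives only the limit > 100000 nM in this assay, not a number. Compound 2 `CCn1nc(C(=O)N[C@H]2COc3ccccc3N(C)C2=S)nc1Cc1ccccc1` also reaches only the limit > 100000 nM there. Compound 3 `COCCn1nc(C(=O)N[C@H]2COc3ccccc3N(C)C2=S)nc1Cc1ccccc1` likewise stays at the limit > 100000 nM. Hence a step that the two limits leave unreadable from compound 1 to compound 2 and a step that the two limits leave unreadable from compound 1 to compound 3 cannot be sized, and a step that the two limits leave unreadable from compound 2 to compound 3 is equally unreadable, because of the limit of > 100000 nM in this assay, at which 3 of the 3 values shown sit. Compound 4 `CN1C(=S)[C@@H](NC(=O)c2nc(Cc3ccccc3)n(CCCC(F)(F)F)n2)COc2ccccc21` carries 3,3,3-trifluoropropyl in place of hydrogen on a saturated chain carbon bound to an aromatic nitrogen. The measured steps all placed a chain at this same position, and none moved the read-out off the limit. For compound 4 the same outcome is expected, a step that the limit leaves unreadable from compound 1 to compound 4, giving an estimate of 150000 nM with a range from 60000 nM to 400000 nM.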

Compound 4, half-maximal cytotoxic concentration: > 100000 nM
Compound 4 was reported as a limit; the forecaster's own chance of this, stated with the estimate: 85%; the middle value is on the limit's open side.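

In this assay compound 4 also gives only a limit, so its steps from compounds 1, 2 and 3 cannot be read: the limit of > 100000 nM in this assay, at which 4 of the 4 values shown sit. Going by these compounds, whether any of these chains changes toxicity at all stays open.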